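The compounds below may be only part of what the source reports. "The series", "measured", "known", "first", "only" and "open" are said of these compounds alone.

Measured in a functional assay on CCRF-CEM cells (Homo sapiens) for inhibition, read by MTT assay, with a stated time of 72 h; on this read-out lower numbers stand for stronger inhibition and higher numbers for weaker inhibition:
- Compound 1 `COc1cc(NC(C)CCCNC(=O)Nc2ccc(Br)cc2)c2ncccc2c1`: 23000 nM
- Compound 2 `COc1cc(NC(C)CCCNC(=O)NNC(=O)Nc2cccc(F)c2)c2ncccc2c1`: 98000 nM

Compound 2, at 98000 nM, has the higher of the two numbers. Compound 3 `COc1cc(NC(C)CCCNC(=O)NNC(=O)Nc2ccc(O)cc2)c2ncccc2c1` carries 4-hydroxyphenyl in place of 3-fluorophenyl on an amide-type nitrogen. Among the compounds with values here, the only measured step, a 4.3-fold higher number from compound 1 to compound 2 (0.63 log units; beyond the scatter), is modest and replaces a larger piece of the molecule, so it bears only loosely on this change. Within the data shown here, no measured step isolates this swap, so no shift beyond the scatter is expected in this assay. The estimated step is a 1.4-fold lower number from compound 2 to compound 3 (0.15 log units; within the scatter). For compound 3 the expected value is 70000 nM, with an estimated range of 25000 nM to 180000 nM.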

Compound 3, half-maximal inhibitory concentration: 111000 nM
The estimate for compound 3 lay 1.6-fold (0.20 log units) below the measured number, within the range that was stated.
By their numbers in this assay, from the lowest: compound 1; then compounds 2 and 3 (each within the scatter of the next).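

In this assay, 4-hydroxyphenyl in place of 3-fluorophenyl on the amide-type nitrogen gives a 1.1-fold higher number from compound 2 to compound 3 (0.05 log units; within the scatter) and so does not separate the two compounds, although the entering group adds a hydrogen-bond donor and acceptor. The larger replacement gives a 4.8-fold higher number from compound 1 to compound 3 (0.68 log units; beyond the scatter) with this group as well, so the gap from compound 1 also appears with 4-hydroxyphenyl. No evidence here accounts for either result. The compounds shown leave open whether an amine or a carboxylic acid on this phenyl ring would give a number beyond the scatter of compound 2.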